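Swapping Chlorophenyl for Cyanophenyl: Expected Cell Tolerance

The source may hold more compounds than are shown below. What is called first, only, known or untested is meant among the compounds shown, and "the series" means these compounds.

Within the data shown here, compound 1 `Cc1cc(-c2ccccc2Cl)cc(C)c1Oc1cc(N)nc(Nc2ccc(C#N)cc2)n1` was tested in a toxicity assay on MT4 cells (Homo sapiens) for cytotoxicity, read by MTT assay (a lower number here means that less compound is tolerated, a higher number that more compound is tolerated), and gave 25100 nM, which stands at the top of the two numbers known, although its only neighbour, compound 2 `Cc1cc(-c2cccc(Cl)c2)cc(C)c1Oc1cc(N)nc(Nc2ccc(C#N)cc2)n1`, sits within the scatter of it. In this assay compound 2 gave 22300 nM. Among the measured compounds shown here, the one measured step, a 1.1-fold lower number from compound 1 to compound 2 (0.05 log units; within the scatter), placed 3-chlorophenyl in place of 2-chlorophenyl on an aromatic carbon and left the read-out essentially where it was.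

Compound 3 `Cc1cc(-c2ccc(C#N)cc2)cc(C)c1Oc1cc(N)nc(Nc2ccc(C#N)cc2)n1` has not yet been measured. It differs from compound 1 by 4-cyanophenyl in place of 2-chlorophenyl on an aromatic carbon. For the measured compounds named here, the single step available bears on this change only loosely: it concerns the same ring position but a different substituent, and it showed no movement beyond the scatter. With no other guidance, no step beyond the scatter is expected here either, and the expected step is a 1.0-fold lower number from compound 1 to compound 3 (0.00 log units; within the scatter). Compound 3 is therefore estimated at 25000 nM in this assay, with an expected range from 10000 nM to 60000 nM.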

Compound 3, half-maximal cytotoxic concentration: 18100 nM
Estimate against measurement, compound 3: 1.4-fold (0.14 log units) above; the measured number falls inside the stated range.
By their numbers in this assay, from the lowest: compounds 3, 2 and 1 (each within the scatter of the next).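

Placing a nitrile on the ring at this position, rather than moving a chlorine around it, tests a different kind of substituent for the first time, and the step in this assay is a 1.4-fold lower number from compound 1 to compound 3 (0.14 log units; within the scatter) when 4-cyanophenyl replaces 2-chlorophenyl. Measured against the other chlorinated compound, the same entering group gives a 1.2-fold lower number from compound 2 to compound 3 (0.09 log units; within the scatter) and so also stays inside the scatter, which means that at this aromatic carbon, meta to two methyl groups, the three aryl groups cannot be told apart in this read-out, although only the entering group carries a triple bond and a hydrogen-bond acceptor. The compounds offer no measured information on why the numbers stay so close together.

Going by these compounds, because the nitrile and the change of ring position arrive together in compound 3, the effect of each alone remains open, and 4-chlorophenyl or 2-cyanophenyl would be the pairs that could separate them. On these data alone, all three compounds also carry an aromatic ring at this place, so it remains open whether a carboxylic acid, an amine or a simple alkyl chain there would stay within the same range of cell tolerance.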